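Amide side chain in the series: next step

The source may report more compounds than this note shows. Statements on the series, on what has been measured and on what is new or still open speak of the compounds shown alone.

Among the measured compounds shown here, in a functional assay on EBC-1 cells (Homo sapiens) for antiproliferative activity, with a stated time of 72 h (on this read-out lower numbers stand for stronger inhibition and higher numbers for weaker inhibition), compound 1 `CN1CCN(C(=O)c2ccc(-c3cc(F)c4ncc(Cc5ccc6ncccc6c5)n4c3)cc2F)CC1` gives 869 nM and compound 2 `O=C(NCCCN1CCCC1)c1ccc(-c2cc(F)c3ncc(Cc4ccc5ncccc5c4)n3c2)cc1F` gives 161 nM, the lower of the two numbers so far. Compound 3 `O=C(NC1CCCNC1)c1ccc(-c2cc(F)c3ncc(Cc4ccc5ncccc5c4)n3c2)cc1F` follows from compound 2: piperidin-3-yl in place of 3-(pyrrolidin-1-yl)propyl on an amide-type nitrogen. For the measured compounds named here, only one measured step bears on this, a 5.4-fold lower number from compound 1 to compound 2 (0.73 log units; beyond the scatter), a modest change at the same amide carbonyl. Going by the values given here, no measured compound carries piperidin-3-yl, so the direction is uncertain. A modest rise is expected, with an estimated 1.7-fold higher number from compound 2 to compound 3 (0.24 log units; within the scatter). For compound 3 the estimated value is 280 nM, with an expected range of 80 nM to 900 nM.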

Compound 3, half-maximal inhibitory concentration: 138 nM
Compound 3: the middle estimate sits 2.0-fold (0.31 log units) above what was measured; measured number inside the range.
By their numbers in this assay, from the lowest: compounds 3 and 2 (each within the scatter of the next); then compound 1.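

In this assay, the 3-(pyrrolidin-1-yl)propyl chain on the amide-type nitrogen can give way to piperidin-3-yl without a resolved shift, with a 1.2-fold lower number from compound 2 to compound 3 (0.07 log units; within the scatter). The extended chain is therefore not required at this position, and the piperidin-3-yl amide still stands clear of the 4-methylpiperazin-1-yl amide, with a 6.3-fold lower number from compound 1 to compound 3 (0.80 log units; beyond the scatter). No evidence available here explains either step. On these data alone, whether piperidin-4-yl or 1-methylpiperidin-3-yl on the same nitrogen would hold this level remains open. A shorter 2-(pyrrolidin-1-yl)ethyl chain is equally unresolved.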